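Methoxycarbonyl in place of ethyl, cytotoxicity at the limit

A few compounds are considered here, and "the series" means these few. Any claim that something is new, unique, unknown or untested is made for them only; others in the source may bear on it.

Compound 1 `CCc1ccc(NC(=O)Nc2cc(C)nc3ccccc23)cc1` gives > 25000 nM as a limit
Compound 2 `Cc1cc(NC(=O)Nc2ccc(F)c(F)c2)c2ccccc2n1` gives > 25000 nM as a limit

In an ADME assay on Raji cells (Homo sapiens) for cytotoxicity, with a stated time of 72 h (on this read-out lower numbers stand for an effect already at smaller amounts and higher numbers for an effect only at larger amounts of compound), compound 1 gives > 25000 nM as a limit and not as a number. Neither measured compound gives a number, with the limit of > 25000 nM in this assay, at which 2 of the 2 values shown sit, as the record. Compound 3 `COC(=O)c1ccc(NC(=O)Nc2cc(C)nc3ccccc23)cc1` has methoxycarbonyl in place of ethyl on an aromatic carbon, para to a large group, as methoxycarbonyl in place of ethyl on an aromatic carbon counts. Within the data shown here, no step between measured compounds is available. In this assay no step beyond the scatter is expected, in either direction. The estimated change is a number no higher from compound 1 to compound 3 (the limit leaves the size open) and no more. For compound 3 the estimate is 25000 nM with an expected range from 8000 nM to 50000 nM in this read-out.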

Compound 3, half-maximal effective concentration: 17000 nM
The estimate for compound 3 lay 1.5-fold (0.17 log units) above the measured number; measured number inside the range.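

Methoxycarbonyl in place of ethyl on an aromatic carbon, para to a large group, gives an at least 1.4-fold lower number from compound 1 to compound 3 (0.16 log units; that floor lies within the scatter) in this assay. Among these compounds, compound 3 is thus the first compound here with a number rather than a limit, though this step alone does not establish a real change at this position. The other values shown remain limits: the limit of > 25000 nM in this assay, at which 2 of the 3 values shown sit.

From the compounds shown here alone, the true size of the step remains open, since compound 1 has only a limit. Also open, going by these compounds, is whether a carboxylic acid, an amine or a longer chain at this position would give a number.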